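Swapping an Amide for an Ethyl Amine on a Shared Core

A few compounds are considered here, and "the series" means these few. Any claim that something is new, unique, unknown or untested is made for them only; others in the source may bear on it.

Of the compounds shown here, three have been measured in a functional assay on NCI-H1650 cells (Homo sapiens) for cytotoxicity, read by MTT assay, with a stated time of 72 h; on this read-out lower numbers stand for stronger inhibition and higher numbers for weaker inhibition. Compound 2 `CCC(=O)N1C/C(=C\c2cc(OC)c(OC)c(OC)c2)C(=O)/C(=C/c2cc(OC)c(OC)c(OC)c2)C1` gives 4400 nM, the lowest number of the three, so it is the strongest inhibitor among them. Compound 3 `COc1ccc(/C=C2\CN(C)C/C(=C\c3ccc(OC)c(OC)c3)C2=O)cc1OC` gives 9000 nM, and compound 1 `CCCN1C/C(=C\c2ccc(OC)c(OC)c2)C(=O)/C(=C/c2ccc(OC)c(OC)c2)C1` gives 16000 nM. Compounds 1 and 3 differ only in the group on the ring nitrogen, and the step of a 1.8-fold lower number from compound 1 to compound 3 (0.25 log units; within the scatter) shows that changing the size of an alkyl group there made little difference.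

Compound 4 `CCN1C/C(=C\c2cc(OC)c(OC)c(OC)c2)C(=O)/C(=C/c2cc(OC)c(OC)c(OC)c2)C1` has not yet been measured. It differs from compound 2 in one place: ethyl in place of propanoyl on an amine nitrogen in a ring. Among the measured compounds shown here, this change replaces an amide carbonyl with a simple alkyl group on the ring nitrogen, a kind of change that none of the measured pairs covers directly. For the measured compounds named here, the only related step, from compound 1 to compound 3, concerns two alkyl groups and stayed within the scatter. There is therefore no measured basis for expecting a large shift in either direction, although the loss of the carbonyl leaves the outcome uncertain. Compound 4 is expected to give about 6000 nM, with a likely range from 2000 nM to 18000 nM. The estimated step of a 1.4-fold higher number from compound 2 to compound 4 (0.13 log units; within the scatter) is modest and could fall within the scatter.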

Compound 4, half-maximal inhibitory concentration: 8200 nM
Beside the measured number, compound 4's estimate is 1.4-fold (0.14 log units) below it, within the range that was stated.
By their numbers in this assay, from the lowest: compounds 2, 4, 3 and 1 (each within the scatter of the next, the first and the last beyond it).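

In this assay, among the compounds shown here, a 1.9-fold higher number from compound 2 to compound 4 (0.27 log units; within the scatter) is the first comparison on this core of an amide-forming acyl group, propanoyl, with a plain alkyl group, ethyl, on an amine nitrogen in a ring, and it shows that this change, which also removes the carbonyl, cannot be told apart from the usual scatter of the assay. The earlier pair compared only two alkyl groups at this nitrogen, on a core with a different set of methoxy groups, so the new pair extends the same finding to a different kind of group: in both pairs shown, the step at this nitrogen stays within the scatter. Nothing measured here explains why the carbonyl makes no readable difference.

As far as these compounds go, it remains open whether a longer chain such as hexyl, a benzoyl group or a chain ending in a carboxylic acid on this nitrogen would move the number beyond the scatter. The part played by the methoxy groups on the aromatic rings also remains open, as no pair shown differs in those groups alone.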